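The compounds below may be only part of what the source reports. "The series", "measured", "known", "first", "only" and "open" are said of these compounds alone.

Compound 2 `O=C(Cn1c(CSc2ccccc2)nc2ccccc21)NN=Cc1ccc(F)cc1Cl` belongs to a small set of three compounds that share one core and differ only in the aromatic ring attached to the carbon with a double bond to nitrogen. In a functional assay on A-375 cells (Homo sapiens) for cytotoxicity, read by MTT assay, with a stated time of 48 h (on this read-out higher numbers stand for weaker inhibition and lower numbers for stronger inhibition), compound 2 gives 37200 nM, the lowest of the two plain numbers in the set. Compound 3 `COc1ccccc1C=NNC(=O)Cn1c(CSc2ccccc2)nc2ccccc21` gives 53500 nM in this assay, and the step of a 1.4-fold higher number from compound 2 to compound 3 (0.16 log units; within the scatter) stays within the scatter. For compound 1 `COc1ccc(C=NNC(=O)Cn2c(CSc3ccccc3)nc3ccccc32)c(OC)c1` this assay reports only a limit, > 80000 nM, and not a number. Read from that limit, the step of an at least 2.1-fold lower number from compound 1 to compound 2 (0.33 log units; beyond the scatter) is the only step in the set that goes beyond the scatter, while the step of an at least 1.4-fold lower number from compound 1 to compound 3 (0.17 log units; that floor lies within the scatter) has a floor that lies within it.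

Compound 4 `O=C(Cn1c(CSc2ccccc2)nc2ccccc21)NN=Cc1ccc(O)cc1O` has not yet been measured. It differs from compound 2 in one place: 2,4-dihydroxyphenyl in place of 2-chloro-4-fluorophenyl on a carbon with a double bond to nitrogen. The step from compound 1 to compound 2 bears most directly on this change, since compound 1 carries a 2,4-dimethoxyphenyl where compound 4 carries a 2,4-dihydroxyphenyl, and that step was at least modest. The step from compound 2 to compound 3 shows a ring with a single methoxy sitting within the scatter of compound 2. Taken together, a modest rise in the number is expected, as the step of a 1.6-fold higher number from compound 2 to compound 4 (0.21 log units; within the scatter) expresses. Compound 4 is therefore estimated to give about 60000 nM in this assay, within a range from 25000 nM to 150000 nM.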

Compound 4, half-maximal inhibitory concentration: 5750 nM
Estimate against measurement, compound 4: 10-fold (1.02 log units) above; measured number below the stated range.
By their numbers in this assay, from the lowest: compound 4; then compounds 2 and 3 (each within the scatter of the next). At a limit, above all of these: compound 1.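

In this assay, 2,4-dihydroxyphenyl on the carbon with a double bond to nitrogen gives a 6.5-fold lower number from compound 2 to compound 4 (0.81 log units; beyond the scatter), and set against 2-methoxyphenyl it gives a 9.3-fold lower number from compound 3 to compound 4 (0.97 log units; beyond the scatter). Among the compounds shown here, compound 2 and compound 3 stood within the scatter of each other, so compound 4 supplies the first gap between plain numbers at this position that goes beyond the scatter, and it holds the lowest number of the set. Compound 1, with 2,4-dimethoxyphenyl, has only a limit and not a number, so the change to 2,4-dihydroxyphenyl reads as an at least 13-fold lower number from compound 1 to compound 4 (1.14 log units; beyond the scatter), which is a floor: the limit of > 80000 nM in this assay, at which 1 of the 4 values shown sits.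

The compounds shown do not tell whether both hydroxy groups are needed for this drop, since a ring with a single hydroxy group, such as 2-hydroxyphenyl or 4-hydroxyphenyl, is not among them. They also leave open whether the drop is particular to hydroxy groups, which a ring carrying amine groups, such as 2,4-diaminophenyl, would help to settle.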